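Triazole N-aryl variation in the quinoline ether series

A few compounds are considered here, and "the series" means these few. Any claim that something is new, unique, unknown or untested is made for them only; others in the source may bear on it.

Measured compounds:
compound 1 `COc1cc2c(Oc3ccc(NC(=O)c4cn(-c5ccccc5C)nn4)cc3F)ccnc2cc1OCCCN1CCCCC1` — 3250 nM
compound 2 `COc1cc2c(Oc3ccc(NC(=O)c4cn(-c5ccccc5F)nn4)cc3F)ccnc2cc1OCCCN1CCCCC1` — 1290 nM

Among the compounds with values here, compound 2 gives the lowest number of the two measured so far in a functional assay on MKN-45 cells (Homo sapiens) for cytotoxicity, read by MTT assay, with a stated time of 72 h; on this read-out higher numbers stand for weaker inhibition and lower numbers for stronger inhibition. Within the data shown here, the only step recorded so far is a 2.5-fold lower number from compound 1 to compound 2 (0.40 log units; beyond the scatter), a modest change and beyond the scatter.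

Compound 3 `COc1cc2c(Oc3ccc(NC(=O)c4cn(-c5ccc(Br)cc5)nn4)cc3F)ccnc2cc1OCCCN1CCCCC1` has not yet been measured. It differs from compound 2 by 4-bromophenyl in place of 2-fluorophenyl on an aromatic nitrogen. Among the measured compounds shown here, the measured step from compound 1 to compound 2 exchanges a group on the same phenyl ring, but at a different position, and no measured pair shows what moving a substituent along that ring does. That step therefore bears on the present change only indirectly; it shows that small changes on this phenyl ring shift the number by a modest amount in this assay. Nothing measured points to a direction for compound 3.

The expectation for compound 3 is therefore a number close to that of compound 2, with the step of a 1.2-fold lower number from compound 2 to compound 3 (0.07 log units; within the scatter) within or near the scatter, giving an estimated 1100 nM with a range of 350 nM to 3500 nM.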

Compound 3, half-maximal inhibitory concentration: 150 nM
Estimate against measurement, compound 3: 7.3-fold (0.87 log units) above; the measured number lies below the stated range.
By their numbers in this assay, from the lowest: compound 3; then compound 2; then compound 1.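

In this assay, the aryl group on the aromatic nitrogen of the five-membered aromatic ring proves far more consequential than the earlier pair indicated, with an 8.6-fold lower number from compound 2 to compound 3 (0.93 log units; beyond the scatter) and a 22-fold lower number from compound 1 to compound 3 (1.34 log units; beyond the scatter) both exceeding a 2.5-fold lower number from compound 1 to compound 2 (0.40 log units; beyond the scatter) in size. The 4-bromophenyl group gives the lowest number of the three, and its steps to the 2-fluorophenyl and 2-methylphenyl compounds both lie beyond the scatter, so this position can move the number much further than the earlier exchange of fluoro for methyl showed. Nothing available on these compounds accounts for the gain, which remains an observation on the numbers alone.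

The change exchanges the substituent and its place on the phenyl ring at once, and the compounds shown do not separate the two; 2-bromophenyl and 4-fluorophenyl would divide the step into its two parts. Also open, on these data alone, is whether the gain belongs to bromine specifically or extends to 4-chlorophenyl, 4-methylphenyl, 4-methoxyphenyl or an unsubstituted phenyl.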